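Removing one methoxy group on two related cores

A few compounds are considered here, and "the series" means these few. Any claim that something is new, unique, unknown or untested is made for them only; others in the source may bear on it.

Measured so far in a functional assay on SW-620 cells (Homo sapiens) for inhibition; a higher number here means a weaker inhibitor, a lower number a stronger inhibitor:
compound 1 `COc1ccc(C2NN=C(c3cc(OC)c(OC)c(OC)c3)C2O)cc1` — 2670 nM
compound 2 `COc1ccc(C2NN=C(c3cc(OC)c(OC)c(OC)c3)C2O)cc1OC` — 8630 nM
compound 3 `COc1cc(-c2cc(-c3cc(OC)c(OC)c(OC)c3)[nH]n2)cc(OC)c1OC` — 10000 nM

Compounds 1 and 2 share one core and differ in a single place: hydrogen in place of methoxy on an aromatic carbon. That change gave a 3.2-fold lower number from compound 2 to compound 1 (0.51 log units; beyond the scatter). Compound 3 is built on a different core; how the two cores differ is not broken down here. In this assay compound 3 gives the highest of the three numbers, and its value lies within the scatter of that of compound 2, while it sits beyond the scatter from compound 1.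

Compound 4 `COc1ccc(-c2cc(-c3cc(OC)c(OC)c(OC)c3)[nH]n2)cc1OC` is not yet measured. It differs from compound 3 in one place: hydrogen in place of methoxy on an aromatic carbon. This is the same kind of change as that from compound 2 to compound 1, but not the same: around the place in compound 3 there is, in addition, a methoxy group meta to the changed carbon, which the place in compound 2 did not have.

For the measured compounds named here, the expectation for compound 4 rests on the one step that this kind of change made, namely a 3.2-fold lower number from compound 2 to compound 1 (0.51 log units; beyond the scatter), and on the value of compound 3, 10000 nM. On that footing the step from compound 3 to compound 4 is estimated at a 2.9-fold lower number from compound 3 to compound 4 (0.46 log units; beyond the scatter). Going by the values given here, compound 4 is therefore expected to give about 3500 nM in this assay, with a likely range from 1200 nM to 10000 nM; only one earlier step of this kind is known, and it sits on a different core, so the range is kept wide.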

Compound 4, half-maximal inhibitory concentration: 230 nM
The estimate for compound 4 lay 15-fold (1.18 log units) above the measured number; the whole stated range lies above it.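

In this assay, replacing a methoxy group with hydrogen on compound 3 gave a 43-fold lower number from compound 3 to compound 4 (1.64 log units; beyond the scatter), so the change that had already lowered the number on the core of compound 2 lowered it here as well. The direction therefore held on both cores in this series, but that is all that can be said to have carried over, and two steps set no rule for any further core. The size did not carry over, and the data do not show what sets it, as the two steps differ both in the core and in the methoxy group meta to the changed carbon in compound 3, which the place in compound 2 did not have; the two steps stand clearly apart: the same change on two cores in this assay, a 3.2-fold lower number (0.51 log units; beyond the scatter) from compound 2 to compound 1 and a 43-fold lower number (1.64 log units; beyond the scatter) from compound 3 to compound 4, 13-fold (1.13 log units) apart, beyond the scatter of two such steps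

The compounds shown leave open how much of that gap belongs to the core and how much to the extra methoxy group, which a pair carrying the same ring substitution on both cores could separate. They also leave open whether anything other than hydrogen at this place, such as a fluorine, a hydroxyl, an amine or a longer ethoxy chain, would give a step of similar size on either core.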